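A Single Stereocentre Flipped in a Lipid-Phosphoserine Analogue

The source may hold more compounds than are shown below. What is called first, only, known or untested is meant among the compounds shown, and "the series" means these compounds.

Compound 1 `CCCCCCCCCCCOc1ccccc1CCC(=O)OC[C@H]1OCC=C[C@@H]1OP(=O)(O)OC[C@H](N)C(=O)O` and compound 2 `CCCCCCCC/C=C\CCCCCCCC(=O)O[C@H]1CCCO[C@@H]1COP(=O)(O)OC[C@H](N)C(=O)O` were tested in an assay on HEK293-A cells for agonist activity at putative P2Y purinoceptor 10 (Mus musculus), with a stated time of 1.5 h; a lower number here means a smaller maximal response, a higher number a larger maximal response. In this assay compound 1 gives 7.6%. In this assay compound 2 gives "not active" (no number reported), with no number reported, so it stands with no measured value to compare. Compound 3 `CCCCCCCC/C=C\CCCCCCCC(=O)O[C@@H]1CCCO[C@@H]1COP(=O)(O)OC[C@H](N)C(=O)O` differs from compound 2 as follows: the two compounds have the same atoms and bonds; at least one stereo element is drawn with a configuration in one of them and without one in the other: 1 of 5 stereo elements differ; a stereocentre at a saturated ring carbon is drawn S in compound 2 and R in compound 3. Without a measured step for this change, no direction is known, and any difference could well lie within the scatter. For compound 3 the largest response in this assay is expected to be about 8%, ranging from 0% to 25%.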

Compound 3, largest response reached (Emax), in percent of the reference or control that the assay uses: "not active" (no number reported)
Compound 3 has no reported number here, so the estimate cannot be set against anything.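

Compound 2 and compound 3 both come without a number in this assay, so no step can be read between them. Still open is whether the flipped ring stereocentre changes the maximal response, and one caution applies: the fact that one of compounds 2 and 3 is drawn with a defined configuration and the other without, at the place where they differ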